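Methylating the phenol of a propargylamine inhibitor

The source may report more compounds than this note shows. Statements on the series, on what has been measured and on what is new or still open speak of the compounds shown alone.

Compound 1 `C#CCNCc1cc2ccccc2n1C`: 240 nM
Compound 2 `C#CCNCc1cc2cc(O)ccc2n1C`: 3980 nM

In an assay on isolated protein for inhibition of Amine oxidase [flavin-containing] A (Rattus norvegicus) (on this read-out lower numbers stand for stronger inhibition and higher numbers for weaker inhibition), compound 1 gives 240 nM and compound 2 gives 3980 nM. Within the data shown here, the single step between them, hydroxy in place of hydrogen on an aromatic carbon, is large: a 17-fold higher number from compound 1 to compound 2 (1.22 log units; beyond the scatter). Among the measured compounds shown here, compound 2 therefore stands with the highest number of the two, and its only neighbour is compound 1.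

Compound 3 `C#CCNCc1cc2cc(OC)ccc2n1C` differs from compound 2 by methyl in place of hydrogen on an oxygen on an aromatic ring, read one bond further out as hydroxy to methoxy. For the measured compounds named here, no measured step covers a methyl on an oxygen; the only step at hand is the one from compound 1 to compound 2, which shows that a change at this aromatic carbon can move the number far. That step bears on the methoxy only indirectly. The estimate is that compound 3 lands between compound 1 and compound 2, a step of a 2.7-fold lower number from compound 2 to compound 3 (0.42 log units; beyond the scatter) expected in this assay, with wide uncertainty. Compound 3 is expected to give 1500 nM, in a range from 400 nM to 6000 nM.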

Compound 3, inhibition constant: 0.813 nM
The estimate for compound 3 lay 1800-fold (3.27 log units) above the measured number; measured number outside the range, below it.
By their numbers in this assay, from the lowest: compound 3; then compound 1; then compound 2.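

In this assay, a hydroxy and a methoxy on this aromatic carbon give very different outcomes: methyl in place of hydrogen on the oxygen gives a 4900-fold lower number from compound 2 to compound 3 (3.69 log units; beyond the scatter) and so undoes the loss seen with the hydroxy. The methoxy does more than restore the level of the unsubstituted compound, since it gives a 300-fold lower number from compound 1 to compound 3 (2.47 log units; beyond the scatter) in the opposite direction to a 17-fold higher number from compound 1 to compound 2 (1.22 log units; beyond the scatter) at the same carbon. Nothing at hand offers an explanation for this reversal.

The compounds shown leave open whether the gain is particular to the methoxy or extends to other groups here, such as an ethoxy or a fluorine. They also leave open whether a methoxy on another aromatic carbon of the core would move the number in the same way.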